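The source may report more compounds than this note shows. Statements on the series, on what has been measured and on what is new or still open speak of the compounds shown alone.

Compound 1 `COc1ccccc1N1C(=O)C(C)SC1c1cccc(C(=O)NCCCCc2ccccc2)c1`: 84%
Compound 2 `COc1ccc(OC)c(N2C(=O)CSC2c2cccc(C(=O)NCCCCc3ccccc3)c2)c1`: 48%

In a functional assay on SJSA-1 cells (Homo sapiens) for inhibition, read by CCK-8 assay, with a stated time of 72 h, tested at 1 uM (a lower number here means less inhibition, a higher number more inhibition at the concentration tested (going by the name of the read-out)), compound 2 gives 48%, the lower of the two numbers, while compound 1 gives 84%, higher by a margin beyond the usual scatter. Compound 3 `CCN1C(=O)CSC1c1cccc(C(=O)NCCCCc2ccccc2)c1` has not yet been measured. It differs from compound 2 in one place: ethyl in place of 2,5-dimethoxyphenyl on an amide-type nitrogen in a ring. Going by the values given here, no measured pair shows this kind of change, so its effect on this assay is unknown; an aromatic ring with two acceptors is lost. A decrease beyond the scatter is expected, giving a step of a number 18 percentage points lower from compound 2 to compound 3 (beyond the scatter). Compound 3 is therefore estimated at 30%, within 5% to 60%.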

Compound 3, a percentage reported as inhibition, at one concentration (the size of the read-out at that concentration, not a potency): 3%
Estimate against measurement, compound 3: 27 percentage points above; the measured number lies below the stated range.
By their numbers in this assay, from the lowest: compound 3; then compound 2; then compound 1.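

Ethyl in place of 2,5-dimethoxyphenyl on the amide-type nitrogen in a ring removes nearly all the inhibition in this assay and gives a number 45 percentage points lower from compound 2 to compound 3 (beyond the scatter) as the first one-place step available here. The group on this nitrogen therefore matters greatly to the read-out at the concentration tested. Nothing at hand accounts for the size of this loss.

From the compounds shown here alone, it remains open whether the aromatic ring alone suffices or its methoxy groups also contribute. A plain phenyl or a benzyl on this nitrogen would separate those two readings.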